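This account rests on a few compounds, and the source may have more. Where it says the series, first, only, none or still open, it means among the compounds named here.

Of the compounds shown here, three have been tested in a functional assay on Ramos cells (Homo sapiens) for cytotoxicity, read by CCK-8 assay, with a stated time of 72 h; on this read-out higher numbers stand for weaker inhibition and lower numbers for stronger inhibition. Compound 1 `Cn1cc(NC(=O)c2ncn3ccc(N4CCC[C@@H](N)C4)nc23)c(C(F)F)n1` gives > 50000 nM, which is a limit and not a number. Compound 2 `Cn1cc(NC(=O)c2cnc3ccc(N[C@@H]4CCCNC4)nn23)c(C(F)F)n1` gives 11400 nM. Compound 3 `Cn1cc(NC(=O)c2cnc3ccc(N[C@H]4CCCNC4)nn23)c(C(F)F)n1` gives > 50000 nM, again a limit and not a number. From the compounds shown here alone, compound 3 therefore sits at the limit of > 50000 nM in this assay, at which 2 of the 3 values shown sit, so its true value is unknown.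

Compound 4 `Cn1cc(NC(=O)c2cnc3ccc(N[C@@H]4CCCCNC4)nn23)c(C(F)F)n1` has azepan-3-yl in place of piperidin-3-yl on a nitrogen on an aromatic ring. For the measured compounds named here, no measured step covers this change of ring size. The nearest evidence is an at least 4.3-fold higher number from compound 2 to compound 3 (0.64 log units; beyond the scatter), which goes with the fact that compounds 2 and 3 differ only in the configuration as drawn. That step shows that a change at this saturated ring can move the read-out beyond the scatter.

With that single step as a guide, a modest move towards lower numbers is expected, as the estimated at least 2.5-fold lower number from compound 3 to compound 4 (0.39 log units; beyond the scatter). Another result at the limit would be quite possible. For compound 4 the estimated value is 20000 nM, with an expected range from 5000 nM to 50000 nM.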

Compound 4, half-maximal inhibitory concentration: 7200 nM
Compound 4: middle estimate off by 2.8-fold (0.44 log units), on the high side, within the range that was stated.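

Enlarging the saturated ring on this nitrogen does little when compound 2 is the partner: in this assay the change gives a 1.6-fold lower number from compound 2 to compound 4 (0.20 log units; within the scatter), so a seven-membered ring fits at this position as well as the six-membered ring of compound 2 does. Taken from the other piperidine, the same change gives an at least 6.9-fold lower number from compound 3 to compound 4 (0.84 log units; beyond the scatter), which shows that the azepan-3-yl group clearly separates from the weaker stereoisomer. Compound 3 gives > 50000 nM, which is a limit and not a number.

The compounds shown leave open whether the azepan-3-yl group responds to its drawn configuration as strongly as the piperidin-3-yl group does, since only one form of it appears here. They also leave open how a smaller pyrrolidin-3-yl ring, or a methyl group on the ring nitrogen, would read in this assay.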